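The source may report more compounds than this note shows. Statements on the series, on what has been measured and on what is new or still open speak of the compounds shown alone.

Measured so far: compound 1 `CNC(=O)CCCCCCCn1nc(-c2cnc3[nH]ccc3c2)c2c(N)ncnc21` gives 8990 nM in a functional assay on CNE-2 cells (Homo sapiens) for inhibition, read by MTT assay, with a stated time of 72 h; on this read-out higher numbers stand for weaker inhibition and lower numbers for stronger inhibition; compound 2 `Nc1ncnc2c1c(-c1cnc3[nH]ccc3c1)nn2CCCCCCC(=O)NO` gives 19500 nM; compound 3 `CNC(=O)CCCCCCCn1nc(-c2ccc3oc(N)nc3c2)c2c(N)ncnc21` gives 2250 nM.

Compound 3 carries the lowest number of the three, with its nearest neighbour compound 1 and its furthest compound 2. The change from compound 1 to compound 2 is hydroxycarbamoyl in place of (methylcarbamoyl)methyl on a saturated chain carbon, six bonds along the chain from an aromatic nitrogen, and it made a 2.2-fold higher number from compound 1 to compound 2 (0.34 log units; beyond the scatter). Compound 4 `Nc1nc2cc(-c3nn(CCCCCCC(=O)NO)c4ncnc(N)c34)ccc2o1` is not yet measured; it arises from compound 3 by hydroxycarbamoyl in place of (methylcarbamoyl)methyl on a saturated chain carbon, six bonds along the chain from an aromatic nitrogen, the same change on the same place. The two cores differ by a group of 10 heavy atoms (7 carbon, 2 nitrogen, 1 oxygen; one five-membered aromatic ring with 2 hetero atoms, one six-membered aromatic ring of carbon only) in place of a group of 9 heavy atoms (7 carbon, 2 nitrogen; one five-membered aromatic ring with 1 hetero atom, one six-membered aromatic ring with 1 hetero atom), on an aromatic carbon, which gave a 4.0-fold lower number from compound 1 to compound 3 (0.60 log units; beyond the scatter).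

Within the data shown here, for compound 4 the step in this assay is expected to be about a 2.2-fold higher number from compound 3 to compound 4 (0.35 log units; beyond the scatter), beside the earlier one, resting on the single precedent from compound 1 to compound 2 a 2.2-fold higher number from compound 1 to compound 2 (0.34 log units; beyond the scatter). Compound 4 is therefore estimated at 5000 nM, plausibly between 2000 nM and 12000 nM.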

Compound 4, half-maximal inhibitory concentration: 4360 nM
Compound 4: middle estimate off by 1.1-fold (0.06 log units), on the high side; low and high end bracket the measured number.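

In this assay, hydroxycarbamoyl in place of (methylcarbamoyl)methyl on the core of compound 3 gives a 1.9-fold higher number from compound 3 to compound 4 (0.29 log units; within the scatter), and the step carries over from the other core with no difference in size: the same change on two cores in this assay, a 2.2-fold higher number (0.34 log units; beyond the scatter) from compound 1 to compound 2 and a 1.9-fold higher number (0.29 log units; within the scatter) from compound 3 to compound 4, 1.1-fold (0.05 log units) apart, within the scatter of two such steps. The core change also carries over when hydroxycarbamoyl is present, giving a 4.5-fold lower number from compound 2 to compound 4 (0.65 log units; beyond the scatter), and it matches the earlier step: the same change on two cores in this assay, a 4.0-fold lower number (0.60 log units; beyond the scatter) from compound 1 to compound 3 and a 4.5-fold lower number (0.65 log units; beyond the scatter) from compound 2 to compound 4, 1.1-fold (0.05 log units) apart, within the scatter of two such steps. The two changes therefore read as independent across these four compounds, but two cores do not establish a rule for the series, and these numbers do not show why either change has its effect.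

On these data alone, a third core remains untested here. As far as these compounds go, it is also open whether a carboxylic acid in place of hydroxycarbamoyl, or a longer chain, would follow the same pattern.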